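The source may report more compounds than this note shows. Statements on the series, on what has been measured and on what is new or still open speak of the compounds shown alone.

Measured compounds in an ADME assay on MT4 cells (Homo sapiens) for activation, read by MTT assay (a higher number here means that more compound is tolerated, a lower number that less compound is tolerated), each reported only as a limit of the assay:

compound 1, `CCCCSc1nc(Cc2c(F)cccc2Cl)c(C)c(=O)[nH]1`: > 73000 nM
compound 2, `Cc1c(Cc2c(F)cccc2Cl)nc(SC2CCCC2)[nH]c1=O`: > 71000 nM
compound 3, `CCCCSc1nc(C(C)c2c(F)cccc2Cl)cc(=O)[nH]1`: > 73000 nM

Compound 1 and compound 2 differ by cyclopentyl in place of butyl on a sulfur. Because both values are limits, the step that the two limits leave unreadable from compound 1 to compound 2 cannot be read in size or direction; all that can be said is that neither compound reached a half-maximal cytotoxic concentration within the tested range, see the limit of > 73000 nM in this assay, at which 2 of the 3 values shown sit, and (the limit of > 71000 nM in this assay, at which 1 of the 3 values shown sits).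

Compound 3 shares its atoms with compound 1 but joined differently; the difference between the two cores is not broken down here. In this assay compound 3 also sits at a limit, as do the two other values shown.

Compound 4, `CC(c1cc(=O)[nH]c(SC2CCCC2)n1)c1c(F)cccc1Cl`, is not yet measured. It differs from compound 3 by cyclopentyl in place of butyl on a sulfur, which is the same change as that from compound 1 to compound 2, made at the same kind of place. Going by the values given here, since that earlier step is unreadable, the only guide is that compound 1, compound 2 and compound 3 all stand at the limits given in the limit of > 73000 nM in this assay, at which 2 of the 3 values shown sit, and (the limit of > 71000 nM in this assay, at which 1 of the 3 values shown sits). The step of an at least 1.0-fold lower number from compound 3 to compound 4 (0.01 log units; that floor lies within the scatter) is therefore expected to be flat, and compound 4 is expected to come out as a further limit rather than a number, near 71000 nM, with a plausible range of 40000 nM to 150000 nM.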

Compound 4, half-maximal cytotoxic concentration: > 71000 nM
Compound 4 was reported as a limit; the forecaster's own chance of this, stated with the estimate: 85%; the middle value sits exactly at the limit.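

In this assay compound 4 gives > 71000 nM, a limit of the assay and not a number. Compound 3 also stands at a limit, and the change from butyl to cyclopentyl between compound 3 and compound 4 cannot be read in size or direction. The compounds shown leave open where the half-maximal cytotoxic concentration of each lies, and whether this change shifts it at all.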